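The compounds below may be only part of what the source reports. "The series", "measured", "known", "first", "only" and "open" are said of these compounds alone.

Measured in a physicochemical assay for solubility, using the shake flask method, measured as kinetic solubility, with a stated time of 20 h, at pH 2; a higher number here means a more soluble compound, a lower number a less soluble compound:
Compound 1 `FC(F)(F)c1cccc(-c2nc3cnc(Nc4ccccn4)cc3[nH]2)c1`: 21000 nM
Compound 2 `NC(=O)c1ccc(Nc2cc3[nH]c(-c4cccc(C(F)(F)F)c4)nc3cn2)nc1`: < 5000 nM, a limit and not a number

Compound 2 stands at the limit of < 5000 nM in this assay, at which 1 of the 2 values shown sits, so only a limit is known for it. Compound 3 `CN1CCN(c2ccc(Nc3cc4[nH]c(-c5cccc(C(F)(F)F)c5)nc4cn3)nc2)CC1` has 4-methylpiperazin-1-yl in place of carbamoyl on an aromatic carbon. Among the compounds with values here, only one measured step bears on this change, and it brought that carbamoyl in place of hydrogen: an at least 4.2-fold lower number from compound 1 to compound 2 (0.62 log units; beyond the scatter). Compound 3 gives up the carbamoyl, so, given an at least 4.2-fold lower number from compound 1 to compound 2 (0.62 log units; beyond the scatter), a move to a higher number beyond the scatter is expected in this assay. The expected step is an at least 6.0-fold higher number from compound 2 to compound 3 (0.77 log units; beyond the scatter). For compound 3 the estimate is 30000 nM, within an expected range of 9000 nM to 100000 nM.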

Compound 3, solubility: 190000 nM
The estimate for compound 3 lay 6.3-fold (0.80 log units) below the measured number, outside the stated range (above it).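

In this assay, the position two atoms from the ring nitrogen can carry a group that gives a higher number than either hydrogen or carbamoyl: 4-methylpiperazin-1-yl brings a 9.0-fold higher number from compound 1 to compound 3 (0.96 log units; beyond the scatter) and an at least 38-fold higher number from compound 2 to compound 3 (1.57 log units; beyond the scatter). The only substituent seen there before had given a lower number, so change at this position can move the number either way. The second step starts from a limit and not a number: the limit of < 5000 nM in this assay, at which 1 of the 3 values shown sits.

The compounds shown leave open whether the piperazine ring needs its methyl group, or whether a morpholine or an open-chain dimethylamino group would give a similar number here.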